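The source may report more compounds than this note shows. Statements on the series, on what has been measured and on what is new or still open speak of the compounds shown alone.

Working notes on the series. All three measured compounds share one core and one read-out. In a functional assay on the whole organism (strain Swiss albino) for inhibition, with Mus musculus as the target, with a stated time of 4 h (on this read-out higher numbers stand for an effect only at larger amounts of compound and lower numbers for an effect already at smaller amounts), compound 1 `S=c1[nH]nc(Nc2nc(-c3ccc(Cl)cc3)cs2)n1-c1ccccc1` gives 300 mg/kg. Compound 2 `Cc1ccc(-n2c(Nc3nc(-c4ccccc4)cs3)n[nH]c2=S)cc1` gives 300 mg/kg. Compound 3 `COc1ccccc1-n1c(Nc2nc(-c3ccccc3)cs2)n[nH]c1=S` gives 300 mg/kg, level with compounds 1 and 2 within the scatter. Among the compounds with values here, the only single-point step, no change at the digits printed from compound 2 to compound 3 (within the scatter), shows no movement; compounds 1 and 2 differ in two places, and their two values are alike. Compound 4 `COc1ccccc1-n1c(Nc2nc(-c3ccc([N+](=O)[O-])cc3)cs2)n[nH]c1=S` differs from compound 3 by nitro in place of hydrogen on an aromatic carbon. Within the data shown here, no measured step covers this change, and no change made so far moved the read-out, so the expected step is no change at the digits printed from compound 3 to compound 4 (within the scatter), none beyond the scatter. Compound 4 is estimated at 300 mg/kg, with a range from 150 mg/kg to 600 mg/kg.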

Compound 4, minimum effective dose: 100 mg/kg
Compound 4: the middle estimate sits 3.0-fold (0.48 log units) above what was measured; measured number outside the range, below it.
By their numbers in this assay, from the lowest: compound 4; then compounds 1, 2 and 3 (each within the scatter of the next).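

In this assay, phenyl to 4-nitrophenyl gives a 3.0-fold lower number from compound 3 to compound 4 (0.48 log units; beyond the scatter), a modest step and the first one in the series beyond the scatter. The read-out therefore responds to a change at this position on an aromatic carbon, whereas the step at the aromatic nitrogen, no change at the digits printed from compound 2 to compound 3 (within the scatter), showed no movement. No data on hand account for the nitro effect. Going by these compounds, it remains open whether an amine or a carboxylic acid at this position would lower the number as well, and whether nitro has the same effect alongside 4-methylphenyl on the aromatic nitrogen.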